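This account rests on a few compounds, and the source may have more. Where it says the series, first, only, none or still open, it means among the compounds named here.

Measured so far:
compound 1 `COc1cc(-c2cc(/C=C/C(=O)c3ccc(N)cc3)[nH]n2)cc(OC)c1OC` with -45% in a functional assay on SN12C cells (Homo sapiens) for cytotoxicity, read by sulforhodamine B assay, with a stated time of 48 h, tested at 10 uM; a lower number here means a stronger effect, a higher number a weaker effect of the compound at the concentration tested
compound 2 `COc1ccc(-c2cc(/C=C/C(=O)c3ccc(OC)c(OC)c3)[nH]n2)cc1` with -58%
compound 3 `COc1cc(-c2cc(/C=C/C(=O)c3ccc(Cl)c(Cl)c3)[nH]n2)cc(OC)c1OC` with 56%

Compound 1 stands second highest of the three numbers in this assay. Among the measured compounds shown here, its nearest neighbour is compound 2, which sits lower by a margin beyond the scatter; compound 3 lies far above it, and the one single-point step known, a number 101 percentage points higher from compound 1 to compound 3 (beyond the scatter), is large, arising from the 3,4-dichlorophenyl in place of 4-aminophenyl on a carbonyl carbon.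

Compound 4 `COc1ccc(-c2cc(/C=C/C(=O)c3ccc(N)cc3)[nH]n2)cc1OC` differs from compound 1 elsewhere: hydrogen in place of methoxy on an aromatic carbon. For the measured compounds named here, no measured step bears on a change at this ring; the only measured step concerns the ring on the carbonyl carbon, and compound 2 differs from both compound 1 and compound 4 in more than one place, so its value shows nothing directly about this change. Going by the values given here, with no relevant step, the expectation is for no step beyond the scatter in this assay, with wide uncertainty. The step of a number 5 percentage points higher from compound 1 to compound 4 (within the scatter) is therefore estimated as small. Compound 4 is expected to give about -40%, between -75% and 10%.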

Compound 4, a percentage reported as activity, at one concentration (the size of the read-out at that concentration, not a potency): 14%
Compound 4: middle estimate off by 54 percentage points, on the low side, outside the stated range (above it).
By their numbers in this assay, from the lowest: compound 2; then compound 1; then compound 4; then compound 3.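

In this assay, hydrogen in place of methoxy on an aromatic carbon gives a number 59 percentage points higher from compound 1 to compound 4 (beyond the scatter) and so counts as a large step. The earlier compounds shown here gave a single-place step only on the ring at the carbonyl carbon; this one shows that the ring carrying the methoxy groups also governs the read-out, and that a single methoxy there, ortho to a methoxy group, is not interchangeable with hydrogen at the concentration tested. Nothing at hand gives a reason for this step.

On these data alone, it remains open whether the same change holds when the 4-aminophenyl gives way to 3,4-dichlorophenyl on the carbonyl carbon. As far as these compounds go, it is also open whether the effect follows the methoxy itself: a hydroxy, an ethoxy or a fluorine at this carbon would test that.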